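Phenoxy for fluorophenyl on the shared core

This account rests on a few compounds, and the source may have more. Where it says the series, first, only, none or still open, it means among the compounds named here.

Compound 1 `Fc1ccc(-c2ccc3c(NCCCNCc4ccco4)ccnc3c2)cc1` gives 7760 nM in an ADME assay on HepG2 cells (Homo sapiens) for cytotoxicity, read by luminescence, CellTiter-Glo and ATP content, with a stated time of 72 h; a higher number here means that more compound is needed for the effect, a lower number that less compound is needed. Compound 2 `COc1cccc(CNCCCNc2ccnc3cc(-c4ccc(F)cc4)ccc23)c1O` gives 6840 nM in this assay, the change being a 1.1-fold lower number from compound 1 to compound 2 (0.05 log units; within the scatter). Compound 2 thus carries the lower of the two figures, yet its gap to compound 1 lies within the scatter, so the two compounds are not separated. Compound 3 `COc1cccc(Oc2ccc3c(NCCCNCc4cccc(OC)c4O)ccnc3c2)c1` differs from compound 2 by 3-methoxyphenoxy in place of 4-fluorophenyl on an aromatic carbon. For the measured compounds named here, no measured step touches this position: the single step, from compound 1 to compound 2, concerned the chain end and stayed within the scatter, so no direction can be read from it for this change. The expectation is therefore no step beyond the scatter, with wide uncertainty. Compound 3 is expected to give 7000 nM in this assay, with a range from 2500 nM to 20000 nM. The expected change is a 1.0-fold higher number from compound 2 to compound 3 (0.01 log units; within the scatter).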

Compound 3, half-maximal effective concentration: 5300 nM
Estimate against measurement, compound 3: 1.3-fold (0.12 log units) above; measured number inside the range.
By their numbers in this assay, from the lowest: compounds 3, 2 and 1 (each within the scatter of the next).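

In this assay, for the compounds shown here, the first measured change at this aromatic carbon gives a 1.3-fold lower number from compound 2 to compound 3 (0.11 log units; within the scatter). Going by these compounds alone, the position therefore takes 3-methoxyphenoxy, with 9 heavy atoms and 2 hydrogen-bond acceptors, in place of 4-fluorophenyl, with 7 heavy atoms and none, without separating the two compounds; the one earlier step concerned only the chain end. No supporting data bear on why this exchange leaves the two compounds unseparated.

Still open, from the compounds shown here alone, is whether any group on this aromatic carbon can move the number beyond the scatter, for example a carboxylic acid or an amine. Also open, going by these compounds, is whether 3-methoxyphenoxy behaves the same way when the chain ends in furan-2-yl rather than 2-hydroxy-3-methoxyphenyl.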